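A few compounds are considered here, and "the series" means these few. Any claim that something is new, unique, unknown or untested is made for them only; others in the source may bear on it.

Working notes on the series. In a functional assay on CAKI-1 cells (Homo sapiens) for inhibition, read by sulforhodamine B assay, with a stated time of 48 h (a higher number here means a weaker inhibitor of growth, a lower number a stronger inhibitor of growth), compound 3 `COc1cc(-c2nn(-c3cccc(NC(=O)c4ccc(Cl)c(C(F)(F)F)c4)c3)cc2-c2ccncc2)ccc1Cl` gives 2300 nM, and compound 1 `COc1cc(-c2nn(-c3cccc(NC(=O)c4cccc(C(F)(F)F)c4)c3)cc2-c2ccncc2)ccc1Cl` lies within the scatter of it at 2010 nM. Compound 2 `COc1cc(-c2nn(-c3cccc(NC(=O)Nc4ccc(Cl)c(Cl)c4)c3)cc2-c2ccncc2)ccc1Cl` gives 1120 nM, and a 2.1-fold higher number from compound 2 to compound 3 (0.31 log units; beyond the scatter) is a modest step just beyond the scatter. Compound 4 `COc1cc(-c2nn(-c3cccc(NC(=O)c4ccccc4)c3)cc2-c2ccncc2)ccc1Cl` differs from compound 3 as follows: phenyl in place of 4-chloro-3-(trifluoromethyl)phenyl on a carbonyl carbon. This places phenyl in place of 4-chloro-3-(trifluoromethyl)phenyl on a carbonyl carbon. The closest evidence is a 1.1-fold higher number from compound 1 to compound 3 (0.06 log units; within the scatter), so losing the chloro is expected to matter little. Going by the values given here, no measured step removes the trifluoromethyl, which leaves that part open. In this assay no step beyond the scatter is therefore expected, with a slight lean toward a higher number. The estimated change is a 1.2-fold higher number from compound 3 to compound 4 (0.09 log units; within the scatter). For compound 4 the estimated value is 2800 nM, with an expected range from 1200 nM to 6500 nM.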

Compound 4, concentration for 50% growth inhibition: 1160 nM
Compound 4: middle estimate off by 2.4-fold (0.38 log units), on the high side, outside the stated range (below it).
By their numbers in this assay, from the lowest: compounds 2, 4, 1 and 3 (each within the scatter of the next, the first and the last beyond it).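

In this assay, stripping the ring on the carbonyl carbon down to phenyl gives a 2.0-fold lower number from compound 3 to compound 4 (0.30 log units; within the scatter), and removing the trifluoromethyl alone gives a 1.7-fold lower number from compound 1 to compound 4 (0.24 log units; within the scatter), so neither substituent is shown to be required for growth inhibition at this position. The plain phenyl amide also sits level with the urea, at a 1.0-fold higher number from compound 2 to compound 4 (0.02 log units; within the scatter), although compound 3 was separated from compound 2 by a step beyond the scatter. Nothing measured here explains these steps.

Open, on these data alone, is whether an amine or a carboxylic acid on this phenyl would shift the number beyond the scatter.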